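The source may hold more compounds than are shown below. What is called first, only, known or untested is meant among the compounds shown, and "the series" means these compounds.

Compound 1 `O=C1C=C(Nc2ccc(I)cc2)C(=O)c2c1nc1n2[C@H]2OC[C@@H](O)[C@H]2OC1` is the reference point. In a functional assay on MCF7 cells (Homo sapiens) for inhibition, read by sulforhodamine B assay (on this read-out higher numbers stand for weaker inhibition and lower numbers for stronger inhibition), compound 1 gives 2230 nM, the lowest of the two numbers that appear in this set, and the nearest of them belongs to compound 2 `Cc1ccc(NC2=CC(=O)c3c(nc4n3[C@H]3OC[C@@H](O)[C@H]3OC4)C2=O)cc1C`, which in this assay gives 4950 nM, a higher number that lies beyond the scatter. Compound 3 `CCOc1ccccc1NC1=CC(=O)c2c(nc3n2[C@H]2OC[C@@H](O)[C@H]2OC3)C1=O` is recorded in this assay only as a limit of the assay, > 4000 nM. This reflects (the limit of > 4000 nM in this assay, at which 1 of the 3 values shown sits). For the measured compounds named here, the one single-point change among the measured compounds, a step that the limit leaves unreadable from compound 2 to compound 3, is therefore of no readable size, and it concerns a different part of the molecule from the change that follows.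

Compound 4 `O=C1C=C(Nc2ccc(Br)cc2)C(=O)c2c1nc1n2[C@H]2OC[C@@H](O)[C@H]2OC1` differs from compound 1 in one place: bromo in place of iodo on an aromatic carbon. Going by the values given here, no measured step addresses a swap of one halogen for another on that ring, so nothing here points in either direction. The account therefore expects a step from compound 1 to compound 4 that stays within the scatter of the assay, or at most a modest drift towards a higher number, a 1.3-fold higher number from compound 1 to compound 4 (0.10 log units; within the scatter). For compound 4 in this assay the expected value is estimated at 2800 nM, with a range from 1300 nM to 6000 nM.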

Compound 4, half-maximal inhibitory concentration: 2580 nM
Estimate against measurement, compound 4: 1.1-fold (0.04 log units) above; the measured number falls inside the stated range.
By their numbers in this assay, from the lowest: compounds 1, 4 and 2 (each within the scatter of the next, the first and the last beyond it).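

In this assay the change from iodo to bromo gives a 1.2-fold higher number from compound 1 to compound 4 (0.06 log units; within the scatter) and so leaves two compounds that this read-out cannot tell apart. For the compounds shown here, this is the first step in the set whose size can be read, and it gives the first direct information about the substituent on an aromatic carbon para to a large group: here, with the rest of the molecule unchanged, one halogen can stand in for the other without a change that exceeds the usual scatter of the assay. The result covers only this single exchange on the 4-iodophenyl group, and none of the measurements shown offers a reason for it.

As far as these compounds go, it remains open whether the same tolerance extends to chloro or fluoro at this place, or to a group of another kind altogether, such as a hydroxyl, an amine or a carboxylic acid. From the compounds shown here alone, it is also open whether a halogen on another carbon of that ring, or a longer chain in place of the halogen, would keep the read-out in the same range.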